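Swapping chloromethyl for 2-phenylethenyl on a carbonyl carbon

The compounds below may be only part of what the source reports. "The series", "measured", "known", "first", "only" and "open" are said of these compounds alone.

Compound 1 `CCN(CC)c1ccc2cc(C(=O)c3ccc(N4CCN(C(=O)CN5CCNCC5)CC4)cc3)oc2c1` gives 1220 nM in a functional assay on SGC-7901 cells (Homo sapiens) for cytotoxicity, read by MTT assay, with a stated time of 48 h; on this read-out lower numbers stand for stronger inhibition and higher numbers for weaker inhibition.
Compound 2 `CCN(CC)c1ccc2cc(C(=O)c3ccc(N4CCN(C(=O)CN5CCN(C(=O)CCl)CC5)CC4)cc3)oc2c1` gives 1630 nM in this assay.

Of the two measured compounds, compound 2 holds the higher number, though its gap to compound 1, a 1.3-fold higher number from compound 1 to compound 2 (0.13 log units; within the scatter), lies within the scatter, so the two cannot be ranked. Compound 3 `CCN(CC)c1ccc2cc(C(=O)c3ccc(N4CCN(C(=O)CN5CCN(C(=O)/C=C/c6ccccc6)CC5)CC4)cc3)oc2c1` has not been measured. It differs from compound 2 in one place: 2-phenylethenyl in place of chloromethyl on a carbonyl carbon. Among the compounds with values here, no measured step covers this kind of exchange; the only step available changed the same amine nitrogen in a ring from hydrogen to (chloromethyl)carbonyl and barely moved the read-out. There is thus no evidence that groups at this position shift this assay beyond the scatter. Compound 3 is therefore expected to show a step of a 1.1-fold lower number from compound 2 to compound 3 (0.04 log units; within the scatter), nothing beyond the scatter. The estimate for compound 3 is 1500 nM, with a range from 500 nM to 4500 nM.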

Compound 3, half-maximal inhibitory concentration: 1140 nM
Compound 3: the middle estimate sits 1.3-fold (0.12 log units) above what was measured; the measured number falls inside the stated range.
By their numbers in this assay, from the lowest: compounds 3, 1 and 2 (each within the scatter of the next).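

Exchanging chloromethyl, with its 2 heavy atoms and no ring, for 2-phenylethenyl, with 8 heavy atoms and a six-membered aromatic ring, gives a 1.4-fold lower number from compound 2 to compound 3 (0.16 log units; within the scatter) in this assay and so stays inside the scatter. Set against the bare ring nitrogen, the whole (2-phenylethenyl)carbonyl group gives a 1.1-fold lower number from compound 1 to compound 3 (0.03 log units; within the scatter) and so also stays inside it, meaning that in these three compounds hydrogen, (chloromethyl)carbonyl and (2-phenylethenyl)carbonyl on this nitrogen cannot be told apart in this read-out. Nothing available explains why the number holds so steady.

Still open, as far as these compounds go, is whether an amine or a carboxylic acid at the end of a longer chain on this carbonyl carbon would move the number beyond the scatter. Also open, from the compounds shown here alone, is whether 2-phenylethyl, which lacks the double bond, would read the same as 2-phenylethenyl.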